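Swapping the aryl ester on a bicyclic diol core

This account rests on a few compounds, and the source may have more. Where it says the series, first, only, none or still open, it means among the compounds named here.

Measured compounds:
- compound 1, `COc1cccc(C(=O)O[C@@H]2CO[C@H]3[C@@H]2OC[C@@H]3OC(=O)c2ccccc2OC(C)=O)c1`: 0.0142 h
- compound 2, `CC(=O)Oc1ccccc1C(=O)O[C@H]1CO[C@H]2[C@@H]1OC[C@H]2OC(=O)c1cccnc1`: 0.00617 h
- compound 3, `CC(=O)Oc1ccccc1C(=O)O[C@H]1CO[C@H]2[C@@H]1OC[C@H]2O[N+](=O)[O-]`: 0.00314 h

These three share a core carrying an acetylsalicylate ester and differ only in the group on the other oxygen. In an ADME assay on a cell-free system (plasma, Homo sapiens) for metabolic stability, with Plasma (Rattus norvegicus) as the target, read by HPLC, at pH 7.4 (a lower number here means that the compound disappears faster, a higher number that the compound lasts longer), compound 1 gives the highest number of the three: a 2.3-fold lower number from compound 1 to compound 2 (0.36 log units; beyond the scatter), and a 4.5-fold lower number from compound 1 to compound 3 (0.66 log units; beyond the scatter). The values of compound 2 and compound 3 lie close together, a 2.0-fold lower number from compound 2 to compound 3 (0.29 log units; within the scatter).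

Compound 4, `CC(=O)Oc1ccccc1C(=O)O[C@H]1CO[C@H]2[C@@H]1OC[C@H]2OC(=O)c1ccccc1CO[N+](=O)[O-]`, has not yet been measured. It differs from compound 1 in one place: 2-((nitrooxy)methyl)phenyl in place of 3-methoxyphenyl on a carbonyl carbon.

Both measured changes at this position lowered the number, and the change that kept an aryl ester in place was the smaller one. For the measured compounds named here, compound 4 also keeps an aryl ester, so a step of similar size to the one from compound 1 to compound 2 is to be expected. The expected step is a 1.8-fold lower number from compound 1 to compound 4 (0.25 log units; within the scatter). Compound 4 is thus estimated at 0.008 h, within a range of 0.003 h to 0.02 h.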

Compound 4, half-life: 0.0533 h
Compound 4: middle estimate off by 6.7-fold (0.82 log units), on the low side; the measured number lies above the stated range.
By their numbers in this assay, from the lowest: compounds 3 and 2 (each within the scatter of the next); then compound 1; then compound 4.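

At this carbonyl carbon, the group can raise the number as well as lower it: in this assay, 2-((nitrooxy)methyl)phenyl in place of 3-methoxyphenyl gives a 3.8-fold higher number from compound 1 to compound 4 (0.57 log units; beyond the scatter) and not the drop seen with the other replacements. Set against pyridin-3-yl, the same group gives an 8.6-fold higher number from compound 2 to compound 4 (0.94 log units; beyond the scatter), the largest step in this set. Compounds 1, 2 and 4 all keep an aryl ester, so keeping one does not settle the direction of the change, and nothing shown here explains the rise.

As far as these compounds go, it remains open whether the rise needs the nitrooxy part of the new group or only the substituted phenyl ring. A 2-(hydroxymethyl)phenyl or 2-methylphenyl group on the same carbonyl carbon, or a longer chain carrying the nitrooxy group, would help separate the two.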